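The source may hold more compounds than are shown below. What is called first, only, known or untested is meant among the compounds shown, and "the series" means these compounds.

Measured compounds:
compound 1, `Cc1ccc(C(=O)Nc2cccnc2)cc1`: > 3000 nM
compound 2, `CCC(=O)N[C@@H]1CCCc2c1cncc2N1Cc2cc(Cl)ccc2C1=O`: 5210 nM

In an ADME assay on cells for inhibition of cytochrome P450 11B1, mitochondrial (Homo sapiens), read by HTRF (a lower number here means a stronger inhibitor, a higher number a weaker inhibitor), compound 1 gives > 3000 nM. For compound 1 this value is a limit of the assay and not a number, so compound 1 can be placed only on one side of it, at the limit of > 3000 nM in this assay, at which 1 of the 2 values shown sits. Compound 2, built on a different core, gives 5210 nM in this assay. Compound 3, `O=C(Nc1cccnc1)c1ccc(Cl)cc1`, has not yet been measured. It differs from compound 1 in one place: chloro in place of methyl on an aromatic carbon. Among the measured compounds shown here, no measured pair here shows what such a change does, so the step can only be anticipated. With compound 1 at a limit, the step from compound 1 to compound 3 in this assay is expected to be small, a step that the limit leaves unreadable from compound 1 to compound 3, and unlikely to go beyond the usual scatter in either direction. Compound 3 is therefore estimated at 4000 nM, with a range from 1500 nM to 10000 nM.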

Compound 3, half-maximal inhibitory concentration: > 3000 nM
Compound 3 was reported as a limit (the forecaster's own chance of this, stated with the estimate: 55%); the middle value is on the limit's open side.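

In this assay compound 3 gives > 3000 nM, which is a limit, as is the value of compound 1, so no step between compound 1 and compound 3 can be read: the limit of > 3000 nM in this assay, at which 2 of the 3 values shown sit.

As far as these compounds go, what chloro in place of methyl on an aromatic carbon does in this assay stays open, as neither compound has a number there.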